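Chloro to methoxy on an ester analogue, dose expected to rise

The source may hold more compounds than are shown below. What is called first, only, known or untested is meant among the compounds shown, and "the series" means these compounds.

Compound 1 `O=C(O)c1cnc(-c2ccc(Cl)cc2)[nH]c1=O` is a carboxylic acid whose aromatic ring carries a chloro group. In a functional assay on the whole organism (strain Sprague-Dawley) for inhibition, with Rattus norvegicus as the target, with a stated time of 10 min (a lower number here means that less compound is needed, a higher number that more compound is needed for the effect), compound 1 gives 5 mg/kg. Compound 2 `COc1ccc(-c2ncc(C(=O)O)c(=O)[nH]2)cc1` differs by methoxy in place of chloro on an aromatic carbon. In this assay compound 2 reaches only a limit, > 5 mg/kg. The step of a number no lower from compound 1 to compound 2 (the limit leaves the size open) therefore has an open size, and this rests on (the limit of > 5 mg/kg in this assay, at which 1 of the 3 values shown sits). Compound 3 `CCOC(=O)c1cnc(-c2cc(Cl)ccc2OCC)[nH]c1=O` has a different core, and the difference between the two cores is not broken down here. In this assay compound 3 gives 0.5 mg/kg. Compound 4 `CCOC(=O)c1cnc(-c2cc(OC)ccc2OCC)[nH]c1=O` differs from compound 3 by methoxy in place of chloro on an aromatic carbon. This is the same kind of change as before, but here the place is meta to a large group and para to an ethoxy group, not para to a large group. Guided by compound 1 and its step of a number no lower from compound 1 to compound 2 (the limit leaves the size open), the step of a 3.0-fold higher number from compound 3 to compound 4 (0.48 log units; beyond the scatter) is expected to raise the dose. Compound 4 is estimated at 1.5 mg/kg, between 0.5 mg/kg and 5 mg/kg.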

Compound 4, dose for 50% inhibition: 0.3 mg/kg
Compound 4: the middle estimate sits 5.0-fold (0.70 log units) above what was measured; measured number outside the range, below it.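

In this assay, methoxy in place of chloro on the core of compound 3 gives a 1.7-fold lower number from compound 3 to compound 4 (0.22 log units; within the scatter), which lies within the usual scatter, so on this core the swap shows no clear effect on the dose. Set beside the same change on the core of compound 1, the comparison reads: the same change on two cores in this assay, a number no lower (the limit leaves the size open) from compound 1 to compound 2 and a 1.7-fold lower number (0.22 log units; within the scatter) from compound 3 to compound 4; the limit leaves it open whether they differ. Compound 2 gives only a limit, > 5 mg/kg, so the step on that core cannot be read, and these compounds neither show that the change carries over from one core to the other nor show that it does not.

As far as these compounds go, what remains open is how a different group, such as an amine or a longer chain, would behave on that aromatic carbon of either core.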